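Acyl side chain exchange from compound 1 to compound 3

A few compounds are considered here, and "the series" means these few. Any claim that something is new, unique, unknown or untested is made for them only; others in the source may bear on it.

Measured compounds:
- compound 1 `COc1ccccc1OCC1SCCN1C(=O)CNC(C)=O` gives 40 mg/kg in a functional assay on the whole organism for inhibition, with Cavia porcellus as the target; on this read-out lower numbers stand for an effect already at smaller amounts and higher numbers for an effect only at larger amounts of compound
- compound 2 `CCOC(=O)CC(=O)N1CCS(=O)(=O)C1COc1ccccc1OC` gives 28 mg/kg in this assay

On the numbers available, compound 1 at 40 mg/kg and compound 2 at 28 mg/kg lie within the scatter of each other, so neither can be ranked over the other. Still unmeasured in this assay is compound 3 `CCOC(=O)C(C)(C)C(=O)N1CCSC1COc1ccccc1OC`, which is derived from compound 1 by a single change: 1-(ethoxycarbonyl)-1-methylethyl in place of acetamidomethyl on a carbonyl carbon. Among the compounds with values here, no two measured compounds differ in one place, so no measured step gives the size of this exchange. The evidence is limited to two values that sit close together. No shift beyond the scatter is therefore expected in this assay, in either direction. The expected change is a 1.3-fold lower number from compound 1 to compound 3 (0.10 log units; within the scatter) for this exchange. For compound 3 the estimate is 32 mg/kg with an expected range from 13 mg/kg to 80 mg/kg on this thin evidence.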

Compound 3, dose for half-maximal effect: 61 mg/kg
Beside the measured number, compound 3's estimate is 1.9-fold (0.28 log units) below it; low and high end bracket the measured number.
By their numbers in this assay, from the lowest: compounds 2, 1 and 3 (each within the scatter of the next, the first and the last beyond it).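

In this assay, the exchange of acetamidomethyl for 1-(ethoxycarbonyl)-1-methylethyl on a carbonyl carbon gives a 1.5-fold higher number from compound 1 to compound 3 (0.18 log units; within the scatter), the first measured size of a single change at this position. The place, a carbonyl carbon whose other neighbours are an amide-type nitrogen in a ring, therefore takes a side chain with more heavy atoms and no hydrogen-bond donor without a shift beyond the scatter, so the amide hydrogen of acetamidomethyl is not required to stay within the scatter of compound 1. No accompanying data bear on any property of either group, and this single step gives no explanation for the result.

Going by these compounds, whether this tolerance extends to side chains ending in a carboxylic acid or a basic amine, or to a longer chain than 1-(ethoxycarbonyl)-1-methylethyl, remains open. Also open, on these data alone, is whether the same exchange on the core of compound 2 would give a step of similar size in this assay.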